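Methoxy in Place of Trifluoromethoxy on the Anilino Ring

The compounds below may be only part of what the source reports. "The series", "measured", "known", "first", "only" and "open" are said of these compounds alone.

Within the data shown here, the three compounds measured so far were read in a functional assay on MCF7 cells (Homo sapiens) for cytotoxicity, read by MTT assay, with a stated time of 24 h; a higher number here means a weaker inhibitor, a lower number a stronger inhibitor. Compound 3 `COc1cc2ncnc(Nc3ccc(OC(F)(F)F)cc3)c2cc1OCCCSc1nc2ccccc2o1` gives 9080 nM in this assay, the second highest of the three numbers. Among the measured compounds shown here, compound 2 `COc1cc2ncnc(Nc3ccc(F)c(Cl)c3)c2cc1OCCCSc1nc2ccccc2o1` gives 4050 nM, and the only single-point step measured so far is a 2.2-fold higher number from compound 2 to compound 3 (0.35 log units; beyond the scatter). Compound 1 `COc1ccc(Nc2ncnc3cc(OC)c(OCCCSc4nc5ccccc5s4)cc23)cc1` gives 14200 nM, which lies within the scatter of compound 3.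

The next compound, compound 4 `COc1ccc(Nc2ncnc3cc(OC)c(OCCCSc4nc5ccccc5o4)cc23)cc1`, differs from compound 3 by methyl in place of trifluoromethyl on an oxygen on an aromatic ring. For the measured compounds named here, no measured step covers this exact exchange. The step of a 2.2-fold higher number from compound 2 to compound 3 (0.35 log units; beyond the scatter) shows that changing the group on the anilino ring moves this assay only modestly. Compound 4 shares its 4-methoxyphenyl group with compound 1, which in this assay gives 14200 nM, a number within the scatter of compound 3, although compound 1 differs from compound 4 elsewhere in the molecule.

On this basis compound 4 is expected to show a step of a 1.3-fold higher number from compound 3 to compound 4 (0.12 log units; within the scatter), small and probably within the scatter. The estimate for compound 4 in this assay is 12000 nM, with an expected range from 5000 nM to 30000 nM.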

Compound 4, half-maximal inhibitory concentration: 13100 nM
Beside the measured number, compound 4's estimate is 1.1-fold (0.04 log units) below it; measured number inside the range.
By their numbers in this assay, from the lowest: compound 2; then compounds 3, 4 and 1 (each within the scatter of the next).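

In this assay, among these compounds, methyl in place of trifluoromethyl on the oxygen gives a 1.4-fold higher number from compound 3 to compound 4 (0.16 log units; within the scatter), the first direct reading of this exchange, and it shows that the two groups cannot be told apart at this position. The larger exchange on the same nitrogen behaves differently: 4-methoxyphenyl in place of 3-chloro-4-fluorophenyl gives a 3.2-fold higher number from compound 2 to compound 4 (0.51 log units; beyond the scatter), which, like a 2.2-fold higher number from compound 2 to compound 3 (0.35 log units; beyond the scatter), lies beyond the scatter, so among these three anilino groups only the move away from 3-chloro-4-fluorophenyl registers in this assay. Among the compounds shown here, with 4-methoxyphenyl held constant, 1,3-benzoxazol-2-yl in place of 1,3-benzothiazol-2-yl on the sulfur gives a 1.1-fold lower number from compound 1 to compound 4 (0.04 log units; within the scatter), so this second place also shows no step that can be separated from the scatter.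

The compounds shown leave open whether 3-chloro-4-fluorophenyl would keep its step with 1,3-benzothiazol-2-yl on the sulfur, and whether an amine or a carboxylic acid on the anilino ring, or a longer chain to the sulfur, would move this assay further. Nothing available here explains why any of these steps takes the size it does.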